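Compound 4: tert-butyl in place of methyl on compound 1

A few compounds are considered here, and "the series" means these few. Any claim that something is new, unique, unknown or untested is made for them only; others in the source may bear on it.

Compound 1, `Cc1ccc(Cn2cc(COc3ccc4c(=O)ccoc4c3)nn2)cc1`: 68500 nM in a functional assay on QGY7701 cells (Homo sapiens) for cytotoxicity, read by MTT assay, with a stated time of 48 h; a lower number here means a stronger inhibitor, a higher number a weaker inhibitor.
Compound 2, `O=c1ccoc2cc(OCc3cn(Cc4cccc(F)c4)nn3)ccc12`: > 100000 nM in this assay, a limit of the assay.
Compound 3, `Cc1ccccc1Cn1cc(COc2ccc3c(=O)ccoc3c2)nn1`: > 100000 nM in this assay, a limit of the assay.

Among the measured compounds shown here, compound 1 carries the only number; the other two values are limits, at the limit of > 100000 nM in this assay, at which 2 of the 3 values shown sit. Changing the group on the saturated chain carbon bound to the aromatic nitrogen gives an at least 1.4-fold higher number from compound 1 to compound 2 (0.16 log units; that floor lies within the scatter) and an at least 1.4-fold higher number from compound 1 to compound 3 (0.16 log units; that floor lies within the scatter); both floors lie within the scatter. Between the two limits there is a step that the two limits leave unreadable from compound 2 to compound 3.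

Compound 4, `CC(C)(C)c1ccc(Cn2cc(COc3ccc4c(=O)ccoc4c3)nn2)cc1`, is the next variation at the same part of the molecule. The change is tert-butyl in place of methyl on an aromatic carbon. For the measured compounds named here, no measured step touches this group directly; the two steps from compound 1 that exist both run toward the limit. With every measured step within the scatter or unreadable, no step beyond the scatter is expected in this assay, and the floor of the two steps from compound 1 leaves a weaker number as likely as an unchanged one. Compound 4 is therefore estimated at 90000 nM, between 30000 nM and 300000 nM, which means an expected 1.3-fold higher number from compound 1 to compound 4 (0.12 log units; within the scatter).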

Compound 4, half-maximal inhibitory concentration: > 100000 nM
Compound 4: only a limit was reported; the forecaster's own chance of this, stated with the estimate: 40%; middle value at least 1.1-fold (0.04 log units) from the limit.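

In this assay, the group on the aromatic carbon para to a large group now has its first direct test: tert-butyl, with 4 heavy atoms in place of the 1 of methyl, gives an at least 1.4-fold higher number from compound 1 to compound 4 (0.16 log units; that floor lies within the scatter). Compound 4 gives > 100000 nM, which is a limit of the assay and not a number. Compound 1 therefore remains the only compound in the series with a number, and keeping the substituent at this place while enlarging it to tert-butyl reaches the same limit as the other two variations of the aryl group: the limit of > 100000 nM in this assay, at which 3 of the 4 values shown sit.

Steps among the compounds at the limit cannot be read, and the floor of the step to compound 4 lies within the scatter, so whether compound 4 truly differs from compound 1 remains open. Also open, going by these compounds, is how a methoxy group, an amine or a carboxylic acid on this aromatic carbon would read, and whether any group here could give a number clearly lower than that of compound 1.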